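The compounds below may be only part of what the source reports. "The series", "measured", "known", "first", "only" and "open" are said of these compounds alone.

Measured so far in a functional assay on the whole organism (strain L.) for inhibition, with Echinochloa crus-galli as the target, with a stated time of 72 h, tested at 100 mg/L; on this read-out higher numbers stand for more inhibition of growth at the one concentration tested and lower numbers for less inhibition of growth:

compound 1 `COc1cc(Cl)nc(NC(=S)NC(=O)c2c(-c3ccc(Cl)cc3Cl)noc2C)n1` — 56.3%
compound 2 `Cc1onc(-c2ccc(Cl)cc2Cl)c1C(=O)/N=c1/nc2nc(Cl)cc(C)n2s1` — 55.6%
compound 3 `COc1cc(SC)nc2n/c(=N/C(=O)c3c(-c4ccc(Cl)cc4Cl)noc3C)sn12` — 55.6%

Compound 1 gives 56.3% in this assay, and the values of compound 2 and compound 3 both sit within the usual scatter of it, so nothing separates the three numbers; no ordering among them can be read from these data. Among the measured compounds shown here, no single-point step between measured compounds is available, so the series gives no measured guide to how a change at the amide-type nitrogen moves the read-out.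

Compound 4 `CSc1cc(C)nc(NC(=S)NC(=O)c2c(-c3ccc(Cl)cc3Cl)noc2C)n1` is not yet measured in this assay. It differs from compound 1 in one place: 4-methyl-6-(methylsulfanyl)pyrimidin-2-yl in place of 4-chloro-6-methoxypyrimidin-2-yl on an amide-type nitrogen. The shared core of compound 1 is kept. With three measured values that all agree, the expectation for compound 4 is a step of small size from compound 1, in no fixed direction, and not beyond the scatter: a number 2.3 percentage points lower from compound 1 to compound 4 (within the scatter). For compound 4 in this assay the estimate is 54%, expected to fall between 35% and 72%.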

Compound 4, percent growth inhibition at one concentration: 47.1%
Compound 4: the middle estimate sits 6.9 percentage points above what was measured; low and high end bracket the measured number.
By their numbers in this assay, from the lowest: compounds 4, 2, 3 and 1 (each within the scatter of the next).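

In this assay, among the compounds shown here, 4-methyl-6-(methylsulfanyl)pyrimidin-2-yl in place of 4-chloro-6-methoxypyrimidin-2-yl on the amide-type nitrogen gives the only single-place step now available, a number 9.2 percentage points lower from compound 1 to compound 4 (within the scatter), and so the series has its first measured guide at this position. Even though this exchange alters the group in more than one part, the step stays inside the scatter, so no effect of the change on growth inhibition at the one concentration tested can be claimed. Nothing at hand bears on the cause of the step.

The separate contributions of the parts exchanged within the group cannot be told apart from this single pair. As far as these compounds go, whether an amine such as dimethylamino or a longer chain such as butoxy on this group would give a step beyond the scatter stays open.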